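Cytotoxicity of three purine analogues with a cyclopropylidene side chain

A few compounds are considered here, and "the series" means these few. Any claim that something is new, unique, unknown or untested is made for them only; others in the source may bear on it.

Measured so far:
compound 1, `Nc1nc(OCC(F)(F)F)c2ncn(/C=C3/CC3(CO)CO)c2n1`, > 20000 nM in this assay
compound 2, `Nc1nc(NC2CCCC2)c2ncn(/C=C3/CC3(CO)CO)c2n1`, > 20000 nM in this assay

In an ADME assay on Akata cells (Homo sapiens) for cytotoxicity, with a stated time of 7 days (a lower number here means that less compound is tolerated, a higher number that more compound is tolerated), compound 1 gives > 20000 nM, which is a limit of the assay rather than a number. For compound 2 the result in this assay is again a limit, > 20000 nM. For the measured compounds named here, the only measured step, a step that the two limits leave unreadable from compound 1 to compound 2, therefore cannot be read, and compound 2 stands at the limit of > 20000 nM in this assay, at which 2 of the 2 values shown sit, with no number of its own. Compound 3, `Nc1nc(SCc2ccccc2)c2ncn(/C=C3/CC3(CO)CO)c2n1`, differs from compound 2 by benzylsulfanyl in place of cyclopentylamino on an aromatic carbon. Going by the values given here, no measured step bears on an exchange of a cyclopentylamino for a benzylsulfanyl, so there is nothing to suggest that compound 3 would be tolerated less than the two compounds already measured. Compound 3 is therefore expected to sit at the same limit, an expected step of a number no higher from compound 2 to compound 3 (the limit leaves the size open). The estimate for compound 3 is 20000 nM, within 8000 nM to 40000 nM.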

Compound 3, half-maximal cytotoxic concentration: > 20000 nM
Compound 3 ended at the assay's limit (the forecaster's own chance of this, stated with the estimate: 75%); the middle value lies on the limit itself.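

For the compounds shown here, compound 1, compound 2 and compound 3 all end at a limit of the assay rather than a number, so no step among them can be read: the limit of > 20000 nM in this assay, at which 3 of the 3 values shown sit. The compounds shown leave open how far the three differ in this assay, and at what concentration any of them becomes cytotoxic.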